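Acetyl to tert-butyl in the series: working notes

The source may report more compounds than this note shows. Statements on the series, on what has been measured and on what is new or still open speak of the compounds shown alone.

Measured in a functional assay on A549 cells (Homo sapiens) for inhibition, read by CCK-8 assay, with a stated time of 48 h; on this read-out lower numbers stand for stronger inhibition and higher numbers for weaker inhibition:
- compound 1 `COc1cc(-c2ccnc3cc(-c4ccc5c(ccn5C)c4)nn23)cc(OC)c1OC`: 15 nM
- compound 2 `COc1cc(-c2ccnc3cc(-c4ccc(C(C)=O)cc4)nn23)cc(OC)c1OC`: 4100 nM

Compound 2 holds the higher of the two numbers in this assay. The next step leads to compound 3 `COc1cc(-c2ccnc3cc(-c4ccc(C(C)(C)C)cc4)nn23)cc(OC)c1OC`, with tert-butyl in place of acetyl on an aromatic carbon, para to a large group: tert-butyl in place of acetyl on an aromatic carbon.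

Within the data shown here, only one measured step bears on this change: a 270-fold higher number from compound 1 to compound 2 (2.44 log units; beyond the scatter). It replaces the whole 1-methyl-1H-indol-5-yl group, so it shows that the substituent on the shared core can move the number a long way. Among the measured compounds shown here, no measured pair compares acetyl directly with another small group, so the direction remains uncertain. With compound 2 at the high end, a moderate fall is expected, well short of that large step.

The expected change is a 3.4-fold lower number from compound 2 to compound 3 (0.53 log units; beyond the scatter). The estimate for compound 3 is 1200 nM, with an expected range of 200 nM to 6000 nM.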

Compound 3, half-maximal inhibitory concentration: > 10000 nM
Compound 3: only a limit was reported (the forecaster's own chance of this, stated with the estimate: 10%); middle value at least 8.3-fold (0.92 log units) away from the limit.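

Compound 3 is reported only as a limit of the assay: the limit of > 10000 nM in this assay, at which 1 of the 3 values shown sits. In this assay, among these compounds, tert-butyl in place of acetyl at this position gives an at least 2.4-fold higher number from compound 2 to compound 3 (0.38 log units; beyond the scatter), the first direct comparison of two groups on this phenyl ring; it goes against a fall in the number, and its full size cannot be read from a limit. Against the 1-methyl-1H-indol-5-yl group, the 4-(tert-butyl)phenyl group gives an at least 660-fold higher number from compound 1 to compound 3 (2.82 log units; beyond the scatter), so neither 4-acetylphenyl nor 4-(tert-butyl)phenyl comes near compound 1.

The compounds shown leave open whether another group at this position, such as an amine, a methoxy group or a carboxylic acid, would bring the number closer to that of compound 1. They also leave open which part of the 1-methyl-1H-indol-5-yl group accounts for the gap to these two phenyl groups.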